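The compounds below may be only part of what the source reports. "The series", "measured", "known", "first", "only" and "open" are said of these compounds alone.

Three compounds have been measured in an assay on BTI-TN-5B1-4 cells for inhibition of Amine oxidase [flavin-containing] B (Homo sapiens), read by fluorescence and Amplex Red, using microsomes, with a stated time of 30 min; on this read-out lower numbers stand for stronger inhibition and higher numbers for weaker inhibition:

compound 1, `C#CCOc1cccc(-c2cc(-c3cccc(OCC#C)c3)nc(N)n2)c1`, gives 22100 nM
compound 2, `C#CCOc1ccc(-c2cc(-c3ccccc3OCC#C)nc(N)n2)cc1`, gives 22100 nM
compound 3, `C#CCOc1ccc(-c2cc(-c3ccc(OCC#C)cc3)nc(C)n2)cc1`, gives 7830 nM

Compound 3 stands lowest of the three numbers in this assay. Compound 1 and compound 2 each sit higher than compound 3 by a gap that goes beyond the usual scatter of repeated measurements, while compound 1 and compound 2 cannot be told apart from one another on these numbers.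

Compound 4, `C#CCOc1ccc(-c2cc(-c3ccc(OCC#C)cc3)nc(-c3ccccc3)n2)cc1`, has not yet been measured in this assay. It differs from compound 3 in one place: phenyl in place of methyl on an aromatic carbon. For the measured compounds named here, no measured pair among the three compounds shows the effect of this kind of exchange, so nothing in the data fixes its size or direction. A step of modest size in either direction, or none beyond the scatter, is what can be expected from compound 3 to compound 4 in this assay, and the estimate a 1.3-fold lower number from compound 3 to compound 4 (0.12 log units; within the scatter) reflects that uncertainty. For compound 4 the expected value in this assay is 6000 nM, with a range from 1500 nM to 25000 nM.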

Compound 4, half-maximal inhibitory concentration: 12300 nM
The estimate for compound 4 lay 2.1-fold (0.31 log units) below the measured number; measured number inside the range.
By their numbers in this assay, from the lowest: compounds 3, 4, 1 and 2 (each within the scatter of the next, the first and the last beyond it).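

In this assay the aromatic carbon between two ring nitrogen atoms accepts phenyl in place of methyl with a 1.6-fold higher number from compound 3 to compound 4 (0.20 log units; within the scatter) and this step stays within the usual scatter. For the compounds shown here, this is the first exchange at this position that can be read from a matched pair, and it shows that a six-membered aromatic ring of carbon only can stand here with no difference that these numbers can separate from scatter. The data offer no measured explanation for this result.

Going by these compounds, whether a carboxylic acid, a morpholine or a longer alkyl chain would be accepted at this position remains open, as does the effect of substituents on the entering phenyl. Compound 1 and compound 2 carry an amine at this position but also differ from compound 3 elsewhere, so the effect of the amine cannot be read from them.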